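Working notes: pyridin-2-yl in place of 4-methylphenyl

The compounds below may be only part of what the source reports. "The series", "measured", "known", "first", "only" and "open" are said of these compounds alone.

Measured in a functional assay on HeLa cells (Homo sapiens) for cytotoxicity, read by ELISA, with a stated time of 4 days (a higher number here means a weaker inhibitor, a lower number a stronger inhibitor), as half-maximal inhibitory concentration:
compound 1 `Cc1ccc(-c2cc(-c3ccoc3)cc(-c3ccc(Cl)s3)n2)o1` gives 26500 nM
compound 2 `Cc1ccccc1-c1cc(-c2ccoc2)cc(-c2ccc(Cl)s2)n1` gives 19000 nM
compound 3 `Cc1ccc(-c2cc(-c3ccoc3)cc(-c3ccc(Cl)s3)n2)cc1` gives 28700 nM

Compound 3 lies within the scatter of both other compounds, so these three values give no ranking. The change under study leads from compound 3 to compound 4 `Clc1ccc(-c2cc(-c3ccoc3)cc(-c3ccccn3)n2)s1` and is counted as pyridin-2-yl in place of 4-methylphenyl on an aromatic carbon with pyridin-2-yl in place of 4-methylphenyl on an aromatic carbon next to the ring nitrogen of the shared core.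

All three measured steps exchange the group at this same place. They are a 1.1-fold higher number from compound 1 to compound 3 (0.03 log units; within the scatter) and a 1.5-fold higher number from compound 2 to compound 3 (0.18 log units; within the scatter) and a 1.4-fold lower number from compound 1 to compound 2 (0.14 log units; within the scatter) with none of them beyond the scatter. Across 5-methylfuran-2-yl, 2-methylphenyl and 4-methylphenyl, the values in this assay therefore stay close together. Within the data shown here, no measured compound carries pyridin-2-yl at this place, so this particular exchange remains untested and the range is kept wide.

No step beyond the scatter is expected, and the estimate is a 1.4-fold lower number from compound 3 to compound 4 (0.16 log units; within the scatter) in this read-out. Compound 4 is expected at 20000 nM with an estimated range from 7000 nM to 50000 nM in this assay once measured.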

Compound 4, half-maximal inhibitory concentration: 21600 nM
Compound 4: the middle estimate sits 1.1-fold (0.03 log units) below what was measured, within the range that was stated.
By their numbers in this assay, from the lowest: compounds 2, 4, 1 and 3 (each within the scatter of the next).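

Pyridin-2-yl, counted with a ring nitrogen and a hydrogen-bond acceptor, replaces the all-carbon 4-methylphenyl at this place in this assay, and the result is a 1.3-fold lower number from compound 3 to compound 4 (0.12 log units; within the scatter). The comparisons with the other two groups give a 1.1-fold higher number from compound 2 to compound 4 (0.06 log units; within the scatter) and a 1.2-fold lower number from compound 1 to compound 4 (0.09 log units; within the scatter), so among these four compounds, the set of groups at this place now includes a six-membered aromatic ring with a hetero atom and no step leaves the scatter. No measurement offered here accounts for this flat result, so it stands as an observation only.

All four groups at this place are single aromatic rings, which leaves open whether an amine, a carboxylic acid or a longer alkyl chain on this same aromatic carbon would give a step beyond the scatter. The compounds shown also keep the furan-3-yl group fixed, so they do not show how much that group contributes to the numbers in this assay, or whether pyridin-2-yl would behave the same way with a different group there.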